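The source may hold more compounds than are shown below. What is called first, only, known or untested is meant among the compounds shown, and "the series" means these compounds.

Measured so far:
Compound 1 `Cc1c2c(n3c1CCN(C(=O)[C@H](C)N)CC[C@H](C)Nc1cc-3ccc1C(N)=O)CC(C)(C)CC2=O`: > 100 ug/mL
Compound 2 `Cc1c2c(n3c1CCN(C(=O)[C@@H](N)C(C)C)C[C@@H](C)[C@H](C)Nc1cc-3ccc1C(N)=O)CC(C)(C)CC2=O`: > 100 ug/mL

In a physicochemical assay for solubility, at pH 7.4 (a lower number here means a less soluble compound, a higher number a more soluble compound), compound 1 gives > 100 ug/mL, which is a limit of the assay and not a number. Compound 2 gives > 100 ug/mL, and this too is only a limit. Neither compound therefore has an exact value, and the evidence reads: the limit of > 100 ug/mL in this assay, at which 2 of the 2 values shown sit.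

Compound 3 `Cc1c2c(n3c1CCN(C(=O)[C@H](C)O)C[C@@H](C)[C@H](C)Nc1cc-3ccc1C(N)=O)CC(C)(C)CC2=O` has not yet been measured. It carries 1-hydroxyethyl in place of 1-amino-2-methylpropyl on a carbonyl carbon. Among the measured compounds shown here, no measured pair shows what this exchange does, so the forecast is uncertain. In this assay, a downward move beyond the scatter is expected, and the estimated step of an at least 2.5-fold lower number from compound 2 to compound 3 (0.39 log units; beyond the scatter) reflects that. For compound 3 the estimate is 40 ug/mL, with an expected range of 8 ug/mL to 180 ug/mL.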

Compound 3, solubility: 60 ug/mL
Compound 3: middle estimate off by 1.5-fold (0.18 log units), on the low side; the range from low to high includes it.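

The exchange of 1-amino-2-methylpropyl for 1-hydroxyethyl on a carbonyl carbon can now be sized from one side only, as an at least 1.6-fold lower number from compound 2 to compound 3 (0.22 log units; that floor lies within the scatter) in this assay. Going by these compounds, for compound 2, > 100 ug/mL is a limit of the assay and not a number, so the true step remains unknown. Compound 3, at 60 ug/mL, gives this position its first exact value, while the other values shown stay at a single mark: the limit of > 100 ug/mL in this assay, at which 2 of the 3 values shown sit.

The compounds shown do not separate the exchange of the amine for the hydroxyl from the shortening of the chain, as both change in the same step. On these data alone, how a carboxylic acid or a longer chain on this carbonyl carbon would read in this assay also stays open.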